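This account rests on a few compounds, and the source may have more. Where it says the series, first, only, none or still open, it means among the compounds named here.

Measured so far in a physicochemical assay for solubility, read by HPLC, in phosphate buffer, at pH 7.4 (on this read-out lower numbers stand for lower solubility and higher numbers for higher solubility), as follows
compound 1 `COc1ccc(Nc2nc(NC3CCCC3)c3ccccc3n2)cc1` gives 10.4 ug/mL
compound 2 `COc1ccc(Nc2nc(NCCCO)c3ccccc3n2)cc1` gives 95.6 ug/mL
compound 3 `CCCNc1nc(Nc2ccc(OC)cc2)nc2ccccc12` gives 4.36 ug/mL

Compound 1 stands second highest of the three, with compound 3 lower and compound 2 higher. Compound 4 `COc1ccc(N(C)c2nc(NC3CCCC3)c3ccccc3n2)cc1` differs from it by methyl in place of hydrogen on a nitrogen on an aromatic ring. For the measured compounds named here, no measured step makes this change. The closest guide is a 2.4-fold lower number from compound 1 to compound 3 (0.38 log units; beyond the scatter) (propyl in place of cyclopentyl). The larger steps, a 9.2-fold higher number from compound 1 to compound 2 (0.96 log units; beyond the scatter) and a 22-fold lower number from compound 2 to compound 3 (1.34 log units; beyond the scatter), turn on a hydroxy group that compound 4 lacks. They give no direction for the methyl. In this assay no change beyond the scatter is expected, the estimate being a 1.2-fold higher number from compound 1 to compound 4 (0.06 log units; within the scatter) as the expected step. Compound 4 is estimated at 12 ug/mL (expected range 4 ug/mL to 35 ug/mL) in this read-out.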

Compound 4, solubility: 1.11 ug/mL
Compound 4: the middle estimate sits 11-fold (1.03 log units) above what was measured; measured number below the stated range.
By their numbers in this assay, from the lowest: compound 4; then compound 3; then compound 1; then compound 2.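

In this assay, methyl in place of hydrogen on a nitrogen on an aromatic ring gives a 9.4-fold lower number from compound 1 to compound 4 (0.97 log units; beyond the scatter) and so this nitrogen is a position where a change of 1 heavy atom, with no hydrogen-bond donor or acceptor in the entering group, moves the number beyond the scatter. Earlier steps changed only the other nitrogen substituent. No measurement on the compounds shown accounts for the drop. As far as these compounds go, whether ethyl or a longer chain on this nitrogen continues the drop remains open. So does whether methyl here has the same effect alongside the 3-hydroxypropyl of compound 2.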